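This account rests on a few compounds, and the source may have more. Where it says the series, first, only, none or still open, it means among the compounds named here.

Compound 1 `Cc1ccc(-c2cn(C/C=C3\OC(=O)C(OCc4ccccc4)=C3OCc3ccccc3)nn2)cc1` and compound 2 `O=C1O/C(=C\Cn2cc(-c3cc(F)cc(F)c3)nn2)C(OCc2ccccc2)=C1OCc1ccccc1` share one core and differ in a single place: 3,5-difluorophenyl in place of 4-methylphenyl on an aromatic carbon. In a functional assay on SW-620 cells (Homo sapiens) for antiproliferative activity, read by MTT assay, with a stated time of 72 h (on this read-out higher numbers stand for weaker inhibition and lower numbers for stronger inhibition), compound 1 gives only a limit, > 100000 nM. Compound 2 likewise reaches only a limit in this assay, > 100000 nM. The step that the two limits leave unreadable from compound 1 to compound 2 is thus not a readable size, since the limit of > 100000 nM in this assay, at which 3 of the 3 values shown sit, is where both values sit. Compound 3 `Cc1ccc(-c2cn(C[C@H](O)[C@H]3OC(=O)C(OCc4ccccc4)=C3OCc3ccccc3)nn2)cc1` has a different core, and the difference between the two cores is not broken down here. In this assay compound 3 also gives only a limit, > 100000 nM. Compound 4 `O=C1O[C@H]([C@@H](O)Cn2cc(-c3cc(F)cc(F)c3)nn2)C(OCc2ccccc2)=C1OCc1ccccc1` stands to compound 3 as compound 2 stands to compound 1, the same change at the same place: 3,5-difluorophenyl in place of 4-methylphenyl on an aromatic carbon. Because the limit of > 100000 nM in this assay, at which 3 of the 3 values shown sit, holds every value seen so far, the step that the limit leaves unreadable from compound 3 to compound 4 is expected to leave compound 4 at that limit as well. Compound 4 is accordingly estimated at 150000 nM, expected to fall between 60000 nM and 500000 nM.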

Compound 4, half-maximal inhibitory concentration: > 100000 nM
Compound 4: only a limit was reported (the forecaster's own chance of this, stated with the estimate: 85%); the middle value does not contradict the limit.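

No step can be read from compound 3 to compound 4, as each gives only a limit: the limit of > 100000 nM in this assay, at which 4 of the 4 values shown sit. The compounds shown leave open whether in this assay the 4-methylphenyl and 3,5-difluorophenyl groups differ at all on either core.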